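This account rests on a few compounds, and the source may have more. Where it says the series, first, only, none or still open, it means among the compounds named here.

In a functional assay on HeLa cells (Homo sapiens) for inhibition, read by MTT assay, with a stated time of 48 h (a higher number here means a weaker inhibitor of growth, a lower number a stronger inhibitor of growth), compound 1 `Cn1cc(C2CC(c3ccc(F)cc3)=NN2C(=O)c2cccnc2)c2cc(Br)ccc21` gives 630 nM. Compound 2 `Cn1cc(C2CC(c3ccc(Cl)cc3)=NN2C(=O)c2cccnc2)c2cc(Br)ccc21` differs from it in one place, (chloro in place of fluoro on an aromatic carbon), and in this assay compound 2 gives 5200 nM; that change made an 8.3-fold higher number from compound 1 to compound 2 (0.92 log units; beyond the scatter). Compound 3 `COc1ccc2c(c1)c(C1CC(c3ccc(F)cc3)=NN1C(=O)c1ccc(OC)nc1)cn2C` is built on another core, and how that core differs from the core of compound 1 is not broken down here; in this assay compound 3 gives 410 nM. Compound 4 `COc1ccc2c(c1)c(C1CC(c3ccc(Cl)cc3)=NN1C(=O)c1ccc(OC)nc1)cn2C` is compound 3 carrying the same change, (chloro in place of fluoro on an aromatic carbon), at a place described in the same words as before. For the measured compounds named here, the step expected here is a 6.1-fold higher number from compound 3 to compound 4 (0.79 log units; beyond the scatter), which rests on the one measured guide, namely an 8.3-fold higher number from compound 1 to compound 2 (0.92 log units; beyond the scatter), and is tempered: a single pair is a thin basis. Compound 4 is therefore estimated to give about 2500 nM, most likely between 800 nM and 8000 nM.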

Compound 4, concentration for 50% growth inhibition: 2260 nM
The estimate for compound 4 lay 1.1-fold (0.04 log units) above the measured number; the measured number falls inside the stated range.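

In this assay, going from 4-fluorophenyl to 4-chlorophenyl gave a 5.5-fold higher number from compound 3 to compound 4 (0.74 log units; beyond the scatter), so chloro in place of fluoro weakened growth inhibition on this second core as well. The direction and the size of the step both carried over, and the two steps cannot be told apart: the same change on two cores in this assay, an 8.3-fold higher number (0.92 log units; beyond the scatter) from compound 1 to compound 2 and a 5.5-fold higher number (0.74 log units; beyond the scatter) from compound 3 to compound 4, 1.5-fold (0.18 log units) apart, within the scatter of two such steps. This supports carrying the change between these two cores only; two pairs cannot predict the step on any other core, and they do not show why chloro gives the weaker inhibitor.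

The compounds shown leave open how a nitrile, a trifluoromethyl group or an amine at that same place would compare. They also leave open whether the step would hold on other cell types.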